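The source may report more compounds than this note shows. Statements on the series, on what has been measured and on what is new or still open speak of the compounds shown alone.

In a functional assay on HL-60 cells (Homo sapiens) for inhibition (a lower number here means a stronger inhibitor, a higher number a weaker inhibitor), compound 1 `COc1ccc(-c2cc(=O)n(C(C)C)nc2-c2ccc(OC)cc2)cc1` gives 1320 nM and compound 2 `COc1ccc(-c2cc(=O)n(C)nc2-c2ccc(OC)cc2)cc1` gives 1130 nM with no separation beyond the scatter. Among the measured compounds shown here, compound 2 therefore stands level with compound 1, the only other measured member of the series. Compound 3 `COc1ccc(-c2cc(=O)n(C3CCCC3)nc2-c2ccc(OC)cc2)cc1` has not yet been measured. Its difference from compound 2 is cyclopentyl in place of methyl on an aromatic nitrogen and it falls at the same aromatic nitrogen that separates compound 1 from compound 2. For the measured compounds named here, only one measured step bears on this change. That step is a 1.2-fold lower number from compound 1 to compound 2 (0.07 log units; within the scatter) and it stays within the scatter. Going by the values given here, it shows that exchanging isopropyl and methyl at this nitrogen leaves the number unresolved, but no cyclopentyl compound has been measured, and the new group is larger than either. No step beyond the scatter is expected, and the data indicate no direction, so the range is kept wide on both sides. The estimated step is a 1.1-fold higher number from compound 2 to compound 3 (0.03 log units; within the scatter) and it remains an expectation until measured. Compound 3 is estimated at 1200 nM in this assay with an expected range from 500 nM to 3000 nM for the measurement.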

Compound 3, half-maximal inhibitory concentration: 510 nM
Estimate against measurement, compound 3: 2.4-fold (0.37 log units) above, within the range that was stated.
By their numbers in this assay, from the lowest: compound 3; then compounds 2 and 1 (each within the scatter of the next).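

Replacing the substituent on this aromatic nitrogen can move the number in this assay, which the methyl and isopropyl pair could not show. The cyclopentyl group gives a 2.2-fold lower number from compound 2 to compound 3 (0.35 log units; beyond the scatter) and also a 2.6-fold lower number from compound 1 to compound 3 (0.41 log units; beyond the scatter), so both steps are modest but resolved, and compound 3 is the strongest inhibitor of the three. Among these compounds, the only substituent carrying a ring is also the only one separated from the others, although no information here accounts for that separation.

With a single cyclopentyl compound, the compounds shown cannot tell whether the ring itself matters or whether any group larger than isopropyl would do the same, and a straight pentyl chain set against cyclopentyl, or cyclobutyl and cyclohexyl on either side of it, would separate those readings. From the compounds shown here alone, it also remains open whether the trend continues with a phenyl ring on this nitrogen or survives a hydroxyl or an amine on the cyclopentyl ring, and whether the same step appears with the two 4-methoxyphenyl groups changed.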